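The source may report more compounds than this note shows. Statements on the series, on what has been measured and on what is new or still open speak of the compounds shown alone.

Notes on the series. Compound 1 `C=C(C)[C@@H]1CC=C(C)/C(=N/NC(=O)Nc2nnc(-c3ccc([N+](=O)[O-])cc3)o2)C1` and compound 2 `C=C(C)[C@@H]1CC=C(C)/C(=N/NC(=O)Nc2nnc(-c3ccc(F)cc3)o2)C1` share one core and differ only in fluoro in place of nitro on an aromatic carbon. In a functional assay on the whole organism (strain Swiss albino) with Mus musculus as the target, with a stated time of 4 h (a lower number here means that less compound is needed, a higher number that more compound is needed for the effect), compound 1 gives 300 mg/kg, and compound 2 gives 300 mg/kg; the step of no change at the digits printed from compound 1 to compound 2 (within the scatter) shows that this change left the read-out where it was. Compound 3 `CC(C)=CC/C=C(/C)C/C=N/NC(=O)Nc1nnc(-c2ccc([N+](=O)[O-])cc2)o1` is built on a second core; the difference between the two cores is not broken down here. In this assay compound 3 gives 300 mg/kg, which is level with compounds 1 and 2. Compound 4 `CC(C)=CC/C=C(/C)C/C=N/NC(=O)Nc1nnc(-c2ccc(F)cc2)o1` has not yet been measured. It differs from compound 3 by fluoro in place of nitro on an aromatic carbon, the same change, at the same kind of place, that turns compound 1 into compound 2. For compound 4 in this assay a step of no change at the digits printed from compound 3 to compound 4 (within the scatter) is expected, because the matching change gave no change at the digits printed from compound 1 to compound 2 (within the scatter) on the first core and, level with compounds 1 and 2, compound 3 already stands at 300 mg/kg. The estimate for compound 4 in this assay is therefore 300 mg/kg, with a likely range from 150 mg/kg to 600 mg/kg.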

Compound 4, minimum effective dose: 300 mg/kg
Estimate against measurement, compound 4: no gap at the digits printed; the range from low to high includes it.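

In this assay, fluoro in place of nitro on an aromatic carbon of the second core gives no change at the digits printed from compound 3 to compound 4 (within the scatter). Set beside the matching step on the core of compound 1, the change carries across the two cores in this series without a difference between the steps: the same change on two cores in this assay, no change at the digits printed (within the scatter) from compound 1 to compound 2 and no change at the digits printed (within the scatter) from compound 3 to compound 4, 1.0-fold (0.00 log units) apart, within the scatter of two such steps. This agreement is only between two steps that show no change, and all four compounds stand level, so it does not show whether a step of real size would carry over in the same way, nor does it extend beyond this one pair of groups and these two cores.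

Still open, going by these compounds, is how an amine, a carboxylic acid or a longer chain would read in this assay in the place of nitro or fluoro, on the aromatic carbon para to a large group. Also open, on these data alone, is whether any such group would give a step that differs between the core of compound 1 and the core of compound 3.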